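The source may hold more compounds than are shown below. What is called first, only, known or untested is meant among the compounds shown, and "the series" means these compounds.

Measured in an ADME assay on microsomes from liver (Homo sapiens) for pharmacokinetics; on this read-out lower numbers stand for slow clearance and higher numbers for fast clearance:
- Compound 1 `Cn1cc(-c2ncc(C#N)c(N3C[C@@H]4C[C@H]3CN4C(=O)C3CC3)n2)cn1`: < 16 mL/min/kg
- Compound 2 `C[C@@H]1CN(c2cnc(C#N)c(-c3cnn(C)c3)n2)CCN1C(=O)C1CC1`: < 16 mL/min/kg
- Compound 3 `CC1CC1C(=O)N1CCN(c2nc(-c3cnn(C)c3)ncc2C#N)C[C@H]1C`: < 16 mL/min/kg

Compound 2 gives < 16 mL/min/kg, which is a limit of the assay and not a number. The other two compounds sit at the same limit, so no ranking can be read from these results.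

Compound 4 `C[C@@H]1C[C@H]1C(=O)N1CCN(c2cnc(C#N)c(-c3cnn(C)c3)n2)C[C@H]1C` differs from compound 2 in one place: methyl in place of hydrogen on a saturated ring carbon. Cyclopropylcarbonyl thus becomes (2-methylcyclopropyl)carbonyl.

Compound 3, which has a different core, also carries this group and gives < 16 mL/min/kg, again a limit. On that basis, a step that the limit leaves unreadable from compound 2 to compound 4 is expected to stay within the usual scatter, with no clear direction. For compound 4, the estimated clearance is 12 mL/min/kg, with an expected range of 6 mL/min/kg to 25 mL/min/kg.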

Compound 4, clearance in the Homo sapiens assay: < 16 mL/min/kg
Compound 4 ended at the assay's limit (the forecaster's own chance of this, stated with the estimate: 70%); the middle value is on the limit's open side.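

In the Homo sapiens assay, compound 2 gives < 16 mL/min/kg, which is a limit of the assay and not a number. In the Homo sapiens assay, compound 4 gives < 16 mL/min/kg, which is also a limit of the assay and not a number. No step can be read between compound 2 and compound 4, because both values are limits of the assay and not numbers: the limit of < 16 mL/min/kg in the Homo sapiens assay, at which 4 of the 4 values shown sit.

The compounds shown leave open how fast each one is actually cleared, and so whether methyl in place of hydrogen on a saturated ring carbon changes clearance at all.

In a physicochemical assay for lipophilicity, read by HPLC (a lower number here means a more polar compound, a higher number a more lipophilic compound), compound 2 gives 1.8 and compound 4 gives 1.6. This assay, the physicochemical assay, shows a number 0.20 log units lower from compound 2 to compound 4 (within the scatter).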